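The source may report more compounds than this note shows. Statements on the series, on what has been measured and on what is new or still open speak of the compounds shown alone.

For the measured compounds named here, compound 3 `Cc1cc(C)nc(NS(=O)(=O)c2ccc(N3C(=O)/C(=C/c4coc5ccccc5c4=O)N=C3c3ccccc3)cc2)n1` gives 63200 nM in a functional assay on A549 cells (Homo sapiens) for cytotoxicity, read by sulforhodamine B assay, with a stated time of 72 h (a higher number here means a weaker inhibitor, a lower number a stronger inhibitor), the second highest of the three numbers so far. Its nearest neighbour is compound 1 `O=C1/C(=C/c2coc3ccccc3c2=O)N=C(c2ccc(Cl)cc2)N1c1ccc(S(=O)(=O)Nc2ncccn2)cc1` at 59000 nM, and the furthest is compound 2 `O=C1/C(=C/c2coc3ccccc3c2=O)N=C(c2ccccc2)N1c1ccc(S(=O)(=O)Nc2nccs2)cc1` at 88400 nM; both gaps lie within the scatter, so the three compounds are not separated. Compound 4 `O=C1/C(=C/c2coc3ccccc3c2=O)N=C(c2ccccc2)N1c1ccc(S(=O)(=O)Nc2ncccn2)cc1` carries pyrimidin-2-yl in place of 4,6-dimethylpyrimidin-2-yl on a sulfonamide nitrogen. Going by the values given here, the only measured step at this sulfonamide nitrogen, a 1.4-fold lower number from compound 2 to compound 3 (0.15 log units; within the scatter), exchanged one heteroaryl group for another without leaving the scatter. Compound 1 already bears the pyrimidin-2-yl group and sits within the scatter of compound 3. The step to compound 4 is therefore expected to stay within the scatter, a 1.0-fold lower number from compound 3 to compound 4 (0.01 log units; within the scatter). Compound 4 is estimated at 62000 nM, with a range from 30000 nM to 125000 nM.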

Compound 4, half-maximal inhibitory concentration: 40500 nM
Compound 4: middle estimate off by 1.5-fold (0.18 log units), on the high side, within the range that was stated.
By their numbers in this assay, from the lowest: compounds 4, 1, 3 and 2 (each within the scatter of the next, the first and the last beyond it).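

At the sulfonamide nitrogen, pyrimidin-2-yl and 4,6-dimethylpyrimidin-2-yl are not separated (a 1.6-fold lower number from compound 3 to compound 4 (0.19 log units; within the scatter)). Pyrimidin-2-yl and 1,3-thiazol-2-yl are separated, though only modestly (a 2.2-fold lower number from compound 2 to compound 4 (0.34 log units; beyond the scatter)), and this is the first step at this position to leave the scatter. Hydrogen and chloro on the aromatic carbon are not separated (a 1.5-fold lower number from compound 1 to compound 4 (0.16 log units; within the scatter)). No data here speak to the reason for the gap between compound 2 and compound 4. Open, going by these compounds, is whether a non-aromatic group on the sulfonamide nitrogen, such as acetyl or a longer alkyl chain, would keep or lose this gap.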